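Swapping the Aryl Group on a Shared Core: Cytotoxicity

The compounds below may be only part of what the source reports. "The series", "measured", "known", "first", "only" and "open" are said of these compounds alone.

Two compounds have been measured in an ADME assay on HEL cells (Homo sapiens) for cytotoxicity, with a stated time of 3 days; on this read-out higher numbers stand for lower toxicity in this test and lower numbers for higher toxicity in this test:
Compound 1 `COc1ccc(-c2cc(C)c3ncc(CSCCc4ccccc4)n3c2)cc1` gives 20 ug/mL.
Compound 2 `Cc1cc(-c2cccs2)cn2c(CSCCc3ccccc3)cnc12` gives 20 ug/mL.

Going by the values given here, compound 2 stands level with compound 1 on the numbers so far: the step of no change at the digits printed from compound 1 to compound 2 (within the scatter), which replaced the group on an aromatic carbon of the shared core, stayed within the scatter. Compound 3 `Cc1cc(-c2cccc(O)c2)cn2c(CSCCc3ccccc3)cnc12` has not yet been measured. It differs from compound 2 on an aromatic carbon: 3-hydroxyphenyl in place of thiophen-2-yl on an aromatic carbon. Among the compounds with values here, the only measured step that bears on this change is no change at the digits printed from compound 1 to compound 2 (within the scatter), where exchanging one group for another on that aromatic carbon left the read-out unchanged. On that basis no step beyond the scatter is expected for no change at the digits printed from compound 2 to compound 3 (within the scatter). Compound 3 is therefore estimated to give 20 ug/mL, with a range from 10 ug/mL to 50 ug/mL.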

Compound 3, minimum cytotoxic concentration: 20 ug/mL
Beside the measured number, compound 3's estimate shows no gap at the digits printed; the range from low to high includes it.
By their numbers in this assay, from the lowest: compounds 1, 2 and 3 (each within the scatter of the next).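

In this assay, putting 3-hydroxyphenyl in place of thiophen-2-yl gave no change at the digits printed from compound 2 to compound 3 (within the scatter), and putting it in place of 4-methoxyphenyl gave no change at the digits printed from compound 1 to compound 3 (within the scatter). This aromatic carbon has now carried three different aryl groups with the read-out level among them, and the latest change goes from a five-membered ring containing sulfur and no hydrogen-bond donor to a six-membered carbon ring with one hydrogen-bond donor. Nothing measured here explains why the read-out stays level.

On these data alone, all three groups are aromatic rings, so it remains open whether an amine, a carboxylic acid or a longer chain on this carbon would shift the read-out. Also open, as far as these compounds go, is whether the hydroxyl group's place on the ring matters, which 4-hydroxyphenyl could test.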